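The source may report more compounds than this note shows. Statements on the series, on what has been measured and on what is new or still open speak of the compounds shown alone.

In a functional assay on SGC-7901 cells (Homo sapiens) for cytotoxicity, read by MTT assay, with a stated time of 48 h (on this read-out lower numbers stand for stronger inhibition and higher numbers for weaker inhibition), compound 1 `COc1ccccc1-c1nnc(SCCn2c([N+](=O)[O-])cnc2C)o1` gives 30500 nM, and compound 2 `Cc1ncc([N+](=O)[O-])n1CCSc1nnc(-c2ccccc2Cl)o1` gives 32600 nM, which stands at the higher of these two numbers, though the gap between them lies within the scatter. Compound 3 `Cc1ncc([N+](=O)[O-])n1CCSc1nnc(-c2cccnc2)o1` differs from compound 2 by pyridin-3-yl in place of 2-chlorophenyl on an aromatic carbon. Among the measured compounds shown here, the only measured step, a 1.1-fold higher number from compound 1 to compound 2 (0.03 log units; within the scatter), exchanged one substituent on the same ring and bears only loosely on this change; it showed no movement beyond the scatter. Compound 3 is therefore expected to show a step of a 1.1-fold lower number from compound 2 to compound 3 (0.04 log units; within the scatter), with an estimated 30000 nM in this assay, ranging from 12000 nM to 75000 nM.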

Compound 3, half-maximal inhibitory concentration: 31600 nM
Compound 3: middle estimate off by 1.1-fold (0.02 log units), on the low side, and the stated range covers the measured number.
By their numbers in this assay, from the lowest: compounds 1, 3 and 2 (each within the scatter of the next).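

Exchanging 2-chlorophenyl for pyridin-3-yl at this position gives a 1.0-fold lower number from compound 2 to compound 3 (0.01 log units; within the scatter) in this assay, and exchanging 2-methoxyphenyl for pyridin-3-yl gives a 1.0-fold higher number from compound 1 to compound 3 (0.02 log units; within the scatter). Thus a change of the whole six-membered aromatic ring, including a ring nitrogen in place of carbon, moves nothing beyond the scatter among these three compounds, extending what the earlier swap of one substituent showed. Nothing available explains why the numbers stay together. From the compounds shown here alone, whether a carboxylic acid or an amine on this ring would shift the number beyond the scatter remains open. So does the contribution of the rest of the shared core.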